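Swapping the phenyl of compound 3 for a dienyl chain

The compounds below may be only part of what the source reports. "The series", "measured", "known", "first", "only" and "open" are said of these compounds alone.

Measured so far:
compound 1, `CCCCCCCCCCCCCCNC(=O)[C@@H](N)[C@@H](C)O`, 18700 nM
compound 2, `CCCCCCCCNC(=O)[C@@H](NC(=O)/C=C/c1ccccc1)[C@@H](C)O`, 61400 nM
compound 3, `CCCCCCCCCCCCNC(=O)[C@@H](NC(=O)c1ccccc1)[C@@H](C)O`, 200000 nM

All three were tested in a functional assay on SW-620 cells (Homo sapiens) for cytotoxicity, read by MTT assay, with a stated time of 48 h; a higher number here means a weaker inhibitor, a lower number a stronger inhibitor. Among them compound 3 gives the highest number, so it is the weakest inhibitor of the three; compound 2 gives a lower number, and compound 1 gives the lowest of all. Compound 2 and compound 3 differ in more than one place, so their values can only be set side by side, not traced to a single change.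

Compound 4, `C/C=C/C=C/C(=O)N[C@H](C(=O)NCCCCCCCCCCCC)[C@@H](C)O`, differs from compound 3 in one place: penta-1,3-dien-1-yl in place of phenyl on a carbonyl carbon. Among the measured compounds shown here, no single-change step between measured compounds is known, so the size and direction of this change can only be guessed from where compound 3 stands. The number for compound 4 is expected to move toward a somewhat lower value, a 2.0-fold lower number from compound 3 to compound 4 (0.30 log units; within the scatter), though a result within the scatter of compound 3 would not surprise. The estimate for compound 4 is 100000 nM, with a range from 30000 nM to 300000 nM.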

Compound 4, half-maximal inhibitory concentration: 200000 nM
Estimate against measurement, compound 4: 2.0-fold (0.30 log units) below, within the range that was stated.
By their numbers in this assay, from the lowest: compound 1; then compound 2; then compounds 3 and 4 (each within the scatter of the next).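

Among the compounds shown here, putting penta-1,3-dien-1-yl in place of phenyl on a carbonyl carbon gives no change at the digits printed from compound 3 to compound 4 (within the scatter) in this assay and is the first change here that can be read on its own. At this position, then, an open chain with two double bonds and a six-membered aromatic ring of carbon only cannot be told apart in this assay, so the aromatic ring is not needed to keep the number where it stands. Nothing else measured on these two compounds bears on this result.

On these data alone, whether a different kind of group on this carbonyl carbon, such as a cyclohexyl ring or an aminomethyl group, would move the number remains open. A single pair also cannot show whether the same swap would leave the number unchanged if the rest of the shared core were altered.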